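Thiosemicarbazone series: furan to pyrrole on the imine carbon

The compounds below may be only part of what the source reports. "The series", "measured", "known", "first", "only" and "open" are said of these compounds alone.

Measured compounds:
compound 1 `CC1=CC[C@H](C(C)(C)NC(=S)N/N=C/c2ccccc2)CC1` — 6300 nM
compound 2 `CC1=CC[C@H](C(C)(C)NC(=S)N/N=C/c2ccco2)CC1` — 100 nM

In a functional assay on K562 cells (Homo sapiens) for inhibition, read by sulforhodamine B assay, with a stated time of 48 h (on this read-out lower numbers stand for stronger inhibition of growth and higher numbers for weaker inhibition of growth), compound 2 gives the lower of the two numbers; its nearest neighbour, compound 1, gives 6300 nM, and the step of a 63-fold lower number from compound 1 to compound 2 (1.80 log units; beyond the scatter) separates them. Compound 3 `CC1=CC[C@H](C(C)(C)NC(=S)N/N=C/c2ccc[nH]2)CC1` is not yet measured. It differs from compound 2 by 1H-pyrrol-2-yl in place of furan-2-yl on a carbon with a double bond to nitrogen. For the measured compounds named here, the only measured step that bears on this change is a 63-fold lower number from compound 1 to compound 2 (1.80 log units; beyond the scatter), which exchanged the group on the same carbon, but it replaced a six-membered ring by a five-membered one with a hetero atom; the change to compound 3 keeps a five-membered ring with one hetero atom and only swaps which atom it is. Going by the values given here, no measured step of that kind exists in this set. The expectation for compound 3 is therefore a step of a 1.5-fold higher number from compound 2 to compound 3 (0.18 log units; within the scatter) that stays within the scatter, with no direction favoured. Compound 3 is estimated at 150 nM, with a range of 40 nM to 600 nM in this assay.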

Compound 3, concentration for 50% growth inhibition: 23400 nM
Beside the measured number, compound 3's estimate is 160-fold (2.19 log units) below it, outside the stated range (above it).
By their numbers in this assay, from the lowest: compound 2; then compound 1; then compound 3.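

In this assay, ring size and the count of hetero atoms do not settle the number at the carbon with a double bond to nitrogen: 1H-pyrrol-2-yl in place of furan-2-yl gives a 230-fold higher number from compound 2 to compound 3 (2.37 log units; beyond the scatter) and undoes the whole gain seen with furan-2-yl. The same ring type also ends up on the weak side of phenyl, with a 3.7-fold higher number from compound 1 to compound 3 (0.57 log units; beyond the scatter) in this assay, so a five-membered aromatic ring with one hetero atom does not by itself go with a low number, as compound 3 goes against compound 2. No measurement here explains why these two rings differ so widely.

The compounds shown do not tell whether the gap follows the ring oxygen of furan-2-yl or the hydrogen on the pyrrole nitrogen. A thiophen-2-yl group, or a 1-methylpyrrol-2-yl group with methyl in place of that hydrogen, would help separate the two.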